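A few compounds are considered here, and "the series" means these few. Any claim that something is new, unique, unknown or untested is made for them only; others in the source may bear on it.

Among the compounds with values here, in a functional assay on RS4-11 cells (Homo sapiens) for inhibition, read by CCK-8 assay, with a stated time of 48 h (on this read-out lower numbers stand for stronger inhibition and higher numbers for weaker inhibition), compound 1 (`O=C(Nc1cccc([N+](=O)[O-])c1)N1CCN(S(=O)(=O)c2sccc2-c2ccccc2Oc2ccc(O)c(O)c2)CC1`) gives 9800 nM and compound 2 (`O=C(Nc1ccc([N+](=O)[O-])cc1)N1CCN(S(=O)(=O)c2sccc2-c2ccccc2Oc2ccc(O)c(O)c2)CC1`) gives 14300 nM, so compound 2 stands level with its only neighbour, within the scatter. Compound 3 (`O=[N+]([O-])c1ccc(NC(=S)N2CCN(S(=O)(=O)c3sccc3-c3ccccc3Oc3ccc(O)c(O)c3)CC2)cc1`) keeps the shared core and differs from compound 2 in one place: a group of 12 heavy atoms (7 carbon, 2 nitrogen, 2 oxygen, 1 sulfur; one six-membered aromatic ring of carbon only) in place of a group of 12 heavy atoms (7 carbon, 2 nitrogen, 3 oxygen; one six-membered aromatic ring of carbon only), on an amine nitrogen in a ring. Within the data shown here, no measured step makes this exchange. The nearest guide is a 1.5-fold higher number from compound 1 to compound 2 (0.16 log units; within the scatter), a change within the same group, so no shift beyond the scatter is expected in this assay. The expected step is a 1.3-fold lower number from compound 2 to compound 3 (0.11 log units; within the scatter). For compound 3 the estimated value is 11000 nM, with an expected range of 4000 nM to 30000 nM.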

Compound 3, half-maximal inhibitory concentration: 9000 nM
Compound 3: middle estimate off by 1.2-fold (0.09 log units), on the high side; the range from low to high includes it.
By their numbers in this assay, from the lowest: compounds 3, 1 and 2 (each within the scatter of the next).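

In this assay, putting sulfur in place of the carbonyl oxygen of (4-nitrophenyl)carbamoyl gives a 1.6-fold lower number from compound 2 to compound 3 (0.20 log units; within the scatter), and the same exchange set against the 3-nitrophenyl partner gives a 1.1-fold lower number from compound 1 to compound 3 (0.04 log units; within the scatter), both within the scatter. On this amine nitrogen in a ring, the exchange of one atom therefore leaves the read-out level, as moving the nitro group did. No measured evidence here accounts for this result. Still open, from the compounds shown here alone, is whether an amine or a carboxylic acid in place of the nitro group, or a longer chain on this nitrogen, would shift the number beyond the scatter.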